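This account rests on a few compounds, and the source may have more. Where it says the series, first, only, none or still open, it means among the compounds named here.

Working notes on the series in a functional assay on A549 cells (Homo sapiens) for cytotoxicity, read by sulforhodamine B assay, with a stated time of 72 h; on this read-out higher numbers stand for weaker inhibition of growth and lower numbers for stronger inhibition of growth. Among the compounds with values here, compound 1 (`C=C1CC[C@@H]2[C@](C)(CCC[C@]2(C)C(=O)OC)[C@H]1CCC1=CCc2c(OC(C)=O)ccc(OC(C)=O)c2C1`) gives 510 nM, the only true number among the measured compounds so far. Compound 2 (`C=C1CC[C@@H]2[C@](C)(CCC[C@]2(C)C(=O)OC)[C@H]1CCc1ccc2c(OCc3ccccc3)ccc(OCc3ccccc3)c2c1`) gives > 5000 nM, which is a limit and not a number. Compound 3 (`COC(=O)[C@@]1(C)CCC[C@]2(C)C(CCc3ccc4c(OC)ccc(OC)c4c3)=C(OOC(C)(C)C)CC[C@@H]12`) gives > 18600 nM, which is also a limit and not a number (the limit of > 18600 nM in this assay, at which 1 of the 3 values shown sits). The standing of compound 3 is therefore known only as this limit.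

The next compound is compound 4 (`COC(=O)[C@@]1(C)CCC[C@]2(C)C(CCc3ccc4c(OC)ccc(OC)c4c3)=C(C)CC[C@@H]12`), with methyl in place of (tert-butoxy)oxy on a double-bonded ring carbon. The rest of the structure of compound 3 is unchanged. Within the data shown here, no measured pair contains this change, so its size has no direct precedent. The expectation rests on compound 3 and its limit of > 18600 nM. In this assay, no step beyond the usual scatter is expected, and growth inhibition is expected to stay weak, possibly with only a limit reported again. The expected change is a step that the limit leaves unreadable from compound 3 to compound 4. The estimated value for compound 4 is 20000 nM, with an expected range from 6000 nM to 50000 nM.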

Compound 4, concentration for 50% growth inhibition: > 6700 nM
Compound 4 was reported as a limit (the forecaster's own chance of this, stated with the estimate: 60%); the middle value lies beyond the limit too.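

In this assay, compound 3 and compound 4 are both reported only as limits, and no step can be read between them. The compounds shown leave open whether methyl in place of (tert-butoxy)oxy on a double-bonded ring carbon changes growth inhibition at all, as neither compound has a true number.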